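The compounds below may be only part of what the source reports. "The series", "measured", "known", "first", "only" and "open" are said of these compounds alone.

Measured so far in an ADME assay on HOS cells (Homo sapiens) for cytotoxicity; on this read-out lower numbers stand for higher toxicity in this test and higher numbers for lower toxicity in this test:
compound 1 `CN(C)[C@@H]1CCN(c2cccc3nc(CN(C)[C@H]4CCCc5cccnc54)cn23)C1` — 4900 nM
compound 2 `CCCN(Cc1cn2c(N3CCN(C)CC3)cccc2n1)[C@H]1CCCc2cccnc21` — 6700 nM
compound 3 `CN1CCN(c2cccc3nc(CN(Cc4ccccc4)[C@H]4CCCc5cccnc54)cn23)CC1` — 9300 nM

Compound 1 gives the lowest of the three numbers, but its gap to compound 2 and its gap to compound 3 both lie within the usual scatter, so no order among the three can be read from these values. Going by the values given here, the only step between compounds differing in one place, a 1.4-fold higher number from compound 2 to compound 3 (0.14 log units; within the scatter), is within the scatter as well.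

Compound 4 `CCN1CCN(c2cccc3nc(CN(C)[C@H]4CCCc5cccnc54)cn23)CC1` has not been measured. Its change from compound 1: 4-ethylpiperazin-1-yl in place of 3-(dimethylamino)pyrrolidin-1-yl on an aromatic carbon. Among the compounds with values here, no measured step touches this place on the core; the single measured step, a 1.4-fold higher number from compound 2 to compound 3 (0.14 log units; within the scatter), concerns a group on an amine nitrogen and is small. Within the data shown here, compound 2 and compound 3 differ from compound 1 elsewhere in the molecule, yet their values in this assay remain within the scatter of compound 1, so the series so far shows no movement at all. On that basis no step beyond the scatter is expected for compound 4 in this assay, in either direction. Compound 4 is estimated at 5500 nM, with a range of 2700 nM to 11000 nM. The expected step of a 1.1-fold higher number from compound 1 to compound 4 (0.05 log units; within the scatter) is within the scatter.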

Compound 4, half-maximal cytotoxic concentration: 3900 nM
For compound 4 the middle estimate is 1.4-fold (0.15 log units) above the measured one; the measured number falls inside the stated range.
By their numbers in this assay, from the lowest: compounds 4, 1, 2 and 3 (each within the scatter of the next, the first and the last beyond it).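

In this assay, 4-ethylpiperazin-1-yl in place of 3-(dimethylamino)pyrrolidin-1-yl on the aromatic carbon next to the ring nitrogen gives a 1.3-fold lower number from compound 1 to compound 4 (0.10 log units; within the scatter), the first step read at this position on the shared core. The exchange replaces a five-membered non-aromatic ring with 1 hetero atom and 1 defined stereocentre by a six-membered non-aromatic ring with 2 hetero atoms, while the heavy-atom and hydrogen-bond acceptor counts stay the same, and this read-out shows no change beyond the scatter. No measurement shown explains this outcome.

On these data alone, it remains open whether a substituent at this aromatic carbon of a different kind, such as morpholin-4-yl, a primary amine, a carboxylic acid or a longer open chain ending in a dimethylamino group, would move the number beyond the scatter. With only this one step read at the position, the result also leaves open whether the stereocentre of the 3-(dimethylamino)pyrrolidin-1-yl group matters, as the opposite configuration of that group does not appear in the compounds shown.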